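The source may hold more compounds than are shown below. What is called first, only, known or untested is meant among the compounds shown, and "the series" means these compounds.

Three measured analogues share one core: compound 1 `CC(=O)c1cccc(Nc2ccnc(SCC(=O)c3ccc(-c4ccccc4)cc3)n2)c1`, compound 2 `CC(=O)c1ccc(Nc2ccnc(SCC(=O)c3ccc(Cl)cc3)n2)cc1` and compound 3 `COc1ccc(C(=O)CSc2nccc(Nc3cccc(C(C)=O)c3)n2)cc1`. In a functional assay on HCT-15 cells (Homo sapiens) for inhibition, read by sulforhodamine B assay, with a stated time of 48 h, tested at 10 uM (a lower number here means less inhibition of growth, a higher number more inhibition of growth at the concentration tested), compound 1 gives 15%, compound 3 gives 22% and compound 2 gives 14%, the lowest of the three numbers shown, though both gaps lie within the scatter. Compound 4 `CC(=O)c1ccc(Nc2ccnc(SCC(=O)c3ccc(-c4ccccc4)cc3)n2)cc1` is not yet measured; relative to compound 2 the change is phenyl in place of chloro on an aromatic carbon. For the measured compounds named here, the one measured step at that kind of site, a number 7 percentage points higher from compound 1 to compound 3 (within the scatter), lies within the scatter, and compound 1 with the phenyl already present sits close to compound 2. The expected step is therefore a number 2 percentage points higher from compound 2 to compound 4 (within the scatter), nothing beyond the scatter. Compound 4 is estimated to give 16% in this assay, within 6% to 27%.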

Compound 4, percent growth inhibition at one concentration: 13%
Compound 4: middle estimate off by 3 percentage points, on the high side; measured number inside the range.
By their numbers in this assay, from the lowest: compounds 4, 2, 1 and 3 (each within the scatter of the next).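

In this assay, phenyl in place of chloro on an aromatic carbon, para to a large group, gives a number 1 percentage points lower from compound 2 to compound 4 (within the scatter) and so leaves the two groups indistinguishable at this position. 4-Acetylphenyl in place of 3-acetylphenyl on the nitrogen gives a number 2 percentage points lower from compound 1 to compound 4 (within the scatter) and so adds a second site where the change leaves the read-out unresolved. No supporting measurement bears on these results.

From the compounds shown here alone, whether an amine or a carboxylic acid on that aromatic carbon would move growth inhibition beyond the scatter remains open. Also open, going by these compounds, is whether 4-acetylphenyl and 3-acetylphenyl differ when methoxy replaces phenyl.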